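The source may report more compounds than this note shows. Statements on the series, on what has been measured and on what is new or still open speak of the compounds shown alone.

Compound 1 `O=C(CNC(=O)c1nn(-c2ccccc2)c(=O)c2ccccc12)Nc1nc2ccc(F)cc2s1` gives 470 nM in an assay on L cells for inhibition of Protein-serine O-palmitoleoyltransferase porcupine (Mus musculus), read by reporter gene assay, with a stated time of 24 h; a higher number here means that more compound is needed for the effect, a lower number that less compound is needed. Compound 2 `O=C(CNC(=O)c1nn(-c2ccccc2)c(=O)c2ccccc12)Nc1nccs1` reaches only the limit > 25000 nM in this assay, so for compound 2 no number is known, only (the limit of > 25000 nM in this assay, at which 1 of the 3 values shown sits). Compound 3 `O=C(CSc1nc2c(c(=O)n1-c1ccccc1)SCC2)Nc1ccc(N2CCCCC2)cc1`, built on a different core, gives 30 nM in this assay. Compound 4 `O=C(CNC(=O)c1nn(-c2ccccc2)c(=O)c2ccccc12)Nc1nc2ccc(Cl)cc2s1` differs from compound 2 by 6-chloro-1,3-benzothiazol-2-yl in place of 1,3-thiazol-2-yl on an amide-type nitrogen. Among the compounds with values here, the one measured step that bears on this, an at least 53-fold higher number from compound 1 to compound 2 (1.72 log units; beyond the scatter), went the opposite way, trading a 6-fluoro-1,3-benzothiazol-2-yl for a 1,3-thiazol-2-yl, and pushed the value off the measurable scale. Restoring a fused 6-chloro-1,3-benzothiazol-2-yl group is therefore expected to bring a large step down, an at least 62-fold lower number from compound 2 to compound 4 (1.79 log units; beyond the scatter). Compound 4 is estimated at 400 nM, between 120 nM and 1500 nM.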

Compound 4, half-maximal effective concentration: 30 nM
Compound 4: middle estimate off by 13-fold (1.12 log units), on the high side; the whole stated range lies above it.
By their numbers in this assay, from the lowest: compounds 3 and 4 (each within the scatter of the next); then compound 1. At a limit, above all of these: compound 2.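

The value of compound 2 is a limit of the assay, not a number: the limit of > 25000 nM in this assay, at which 1 of the 4 values shown sits. On the amide-type nitrogen, 6-chloro-1,3-benzothiazol-2-yl still gives an at least 830-fold lower number from compound 2 to compound 4 (2.92 log units; beyond the scatter), so the group's full gain can only be stated as a minimum. New here is that the halogen itself matters: chloro in place of fluoro on an aromatic carbon gives a 16-fold lower number from compound 1 to compound 4 (1.19 log units; beyond the scatter), so the fused ring alone does not set the value in this assay. On these data alone, how a bromo, methyl or methoxy group would compare in that place stays open, as does the fused ring with no halogen at all.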